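Swapping a Chloromethyl for a Dimethylcarbamoyl on the Ring

The source may report more compounds than this note shows. Statements on the series, on what has been measured and on what is new or still open speak of the compounds shown alone.

In a functional assay on SW480 cells (Homo sapiens) for antiproliferative activity, read by MTT assay, with a stated time of 48 h (a higher number here means a weaker inhibitor, a lower number a stronger inhibitor), compound 1 `C=C1/C=C/C(=O)/C(CO)=C\C[C@](C)(CCC=C(C)C)/C=C/[C@H]1OC(=O)C=C(C)C` gives 2970 nM, compound 2 `CC(C)=CCC[C@]1(C)/C=C/[C@@H](OC(=O)C=C(C)C)[C@](C)(O)/C=C/C(=O)/C(CCl)=C\C1` gives 390 nM, and compound 3 `CC(C)=CCC[C@](C)(/C=C/[C@@H](OC(=O)C=C(C)C)[C@](C)(O)/C=C/C(=O)/C=C/N1CCN(C)CC1)CC=O` gives 12400 nM. Compound 2 therefore holds the lowest number of the three, and both gaps, the nearer one to compound 1 and the wider one to compound 3, lie beyond the usual scatter of repeated measurements. The unmeasured compound 4 `CC(C)=CCC[C@]1(C)/C=C/[C@@H](OC(=O)C=C(C)C)[C@](C)(O)/C=C/C(=O)/C(C(=O)N(C)C)=C\C1` keeps the core of compound 2 and differs in one spot only: dimethylcarbamoyl in place of chloromethyl on a double-bonded ring carbon. Among the compounds with values here, no measured pair here differs in a single place, so the size of such a step cannot be read from the data. Compound 4 is expected to be a weaker inhibitor than compound 2, with an estimated step of a 7.7-fold higher number from compound 2 to compound 4 (0.89 log units; beyond the scatter). The estimate for compound 4 is 3000 nM, within a range from 800 nM to 12000 nM.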

Compound 4, half-maximal inhibitory concentration: 3300 nM
Estimate against measurement, compound 4: 1.1-fold (0.04 log units) below; the range from low to high includes it.
By their numbers in this assay, from the lowest: compound 2; then compounds 1 and 4 (each within the scatter of the next); then compound 3.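

In this assay, within the data shown here, dimethylcarbamoyl in place of chloromethyl on the double-bonded ring carbon gives an 8.5-fold higher number from compound 2 to compound 4 (0.93 log units; beyond the scatter), the only step here that changes a single place. This position is therefore not indifferent to the group it carries, and with the rest of the compound unchanged, this exchange gives a weaker inhibitor. Nothing shown here explains the step.

On these data alone, only these two groups can be compared at this carbon, so it remains open how a plain methyl, a carboxylic acid or a smaller primary amide would behave there.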